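This account rests on a few compounds, and the source may have more. Where it says the series, first, only, none or still open, it means among the compounds named here.

Within the data shown here, in a functional assay on HeLa cells (Homo sapiens) for antiproliferative activity, read by MTT assay, with a stated time of 72 h (a higher number here means a weaker inhibitor, a lower number a stronger inhibitor), compound 1 `COc1ccc(N2C(=O)COc3ccc(-c4cnc(Cl)c(NS(=O)(=O)c5ccc(F)cc5)c4)cc32)cc1` gives 8320 nM and holds the higher of the two numbers measured so far. Among the measured compounds shown here, compound 2 `COc1ccc(N2C(=O)COc3ccc(-c4cnc(OC)c(NS(=O)(=O)c5ccc(F)cc5)c4)cc32)cc1` carries methoxy in place of chloro on an aromatic carbon and gives 1220 nM as its value, which makes a 6.8-fold lower number from compound 1 to compound 2 (0.83 log units; beyond the scatter) the only measured step. Compound 3 `O=C1COc2ccc(-c3cnc(Cl)c(NS(=O)(=O)c4ccc(F)cc4)c3)cc2N1C1CC1` keeps that chloro and changes another place instead, with cyclopropyl in place of 4-methoxyphenyl on an amide-type nitrogen in a ring, and the change cyclopropyl in place of 4-methoxyphenyl on an amide-type nitrogen in a ring takes away a larger group than it brings in. For the measured compounds named here, no measured compound differs at this nitrogen, so the modest chloro to methoxy step gives only a rough sense of how far one change can move the number in this assay and says nothing about direction. A step of no more than about that size is expected, leaning towards a weaker inhibitor, although a result within the scatter remains possible. The estimated step is a 2.4-fold higher number from compound 1 to compound 3 (0.38 log units; beyond the scatter) and carries wide uncertainty. Compound 3 is expected at 20000 nM with 6000 nM to 60000 nM as its estimated range.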

Compound 3, half-maximal inhibitory concentration: 7180 nM
For compound 3 the middle estimate is 2.8-fold (0.44 log units) above the measured one; low and high end bracket the measured number.
By their numbers in this assay, from the lowest: compound 2; then compounds 3 and 1 (each within the scatter of the next).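

In this assay, among these compounds, this is the first look at the amide-type nitrogen in a ring, and cyclopropyl in place of 4-methoxyphenyl gives a 1.2-fold lower number from compound 1 to compound 3 (0.06 log units; within the scatter) so compound 1 and compound 3 cannot be told apart. Among the compounds shown here, with the chloro kept, 8 heavy atoms, a six-membered aromatic ring and a hydrogen-bond acceptor leave, only 3 heavy atoms enter, and the number stays within the usual scatter, whereas the one earlier change gave a 6.8-fold lower number from compound 1 to compound 2 (0.83 log units; beyond the scatter) and so this nitrogen, for this pair, shows far less response than the chloro to methoxy swap did. No measurement shown here bears on the reason for this result.

For the compounds shown here, still open is whether the same swap at the nitrogen would hold up on the methoxy compound, since compound 2 is the only compound here with a number clearly separated from the others. Going by these compounds, it is equally open how this nitrogen would respond to a quite different group, such as a plain methyl, a longer chain like n-butyl, or a chain ending in an amine or a carboxylic acid. Two groups cannot show a trend.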